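A larger amine ring on the inner phenyl position

The source may hold more compounds than are shown below. What is called first, only, known or untested is meant among the compounds shown, and "the series" means these compounds.

Three sulfonamides share one core. Compound 1 `Cc1cccc(S(=O)(=O)Nc2ccc(-c3cccc(Cl)c3)nn2)c1` gives 101 nM in an assay on mitochondria from liver for inhibition of kynurenine 3-monooxygenase (Mus musculus), read by LC-MS, with stated times of 5 min and 30 min (a higher number here means a weaker inhibitor, a lower number a stronger inhibitor), compound 2 `Cc1ccc(S(=O)(=O)Nc2ccc(-c3cccc(N(C)C)c3)nn2)cc1` gives 82.5 nM, and compound 3 `Cc1ccc(S(=O)(=O)Nc2ccc(-c3ccccc3N(C)C)nn2)cc1` gives 4.5 nM, the lowest of the three numbers, with both gaps to the others well beyond the scatter. Compound 4 `Cc1ccc(S(=O)(=O)Nc2ccc(-c3ccccc3N3CCN(C)CC3)nn2)cc1` carries 4-methylpiperazin-1-yl in place of dimethylamino on an aromatic carbon, so the change sits on an aromatic carbon of a six-membered aromatic ring of carbon only, ortho to a large group. Within the data shown here, no measured pair shows the effect of such a swap, so the expectation rests on compound 3 alone. A modest weakening is expected, a 3.3-fold higher number from compound 3 to compound 4 (0.52 log units; beyond the scatter), a step likely just beyond the scatter. Compound 4 is expected to give 15 nM, within a range from 4 nM to 60 nM.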

Compound 4, half-maximal inhibitory concentration: > 100 nM
Compound 4: a limit, no number (the forecaster's own chance of this, stated with the estimate: 2%); middle value at least 6.6-fold (0.82 log units) from the limit.
By their numbers in this assay, from the lowest: compound 3; then compounds 2 and 1 (each within the scatter of the next).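

In this assay the swap of dimethylamino for 4-methylpiperazin-1-yl on this aromatic carbon gives an at least 22-fold higher number from compound 3 to compound 4 (1.34 log units; beyond the scatter) and so removes the low number seen with compound 3. This position therefore does not accept every amine, and one change here can decide the result. The reading for compound 4 is a limit of the assay and not a number: the limit of > 100 nM in this assay, at which 1 of the 4 values shown sits.

Going by these compounds, how much higher the true number lies stays open. Nor do the compounds shown separate the effect of the ring from that of its second nitrogen, which a piperidine in the same place could address.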